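Swapping 1H-indol-6-yl for 2-methyl-2H-indazol-6-yl in compound 2

The source may hold more compounds than are shown below. What is called first, only, known or untested is meant among the compounds shown, and "the series" means these compounds.

Measured so far in an ADME assay on microsomes from liver (Mus musculus, strain CD1) for metabolic stability, read by HPLC, with a stated time of 30 min, tested at 0.5 uM (on this read-out lower numbers stand for slow clearance and higher numbers for fast clearance), are two compounds.

- Compound 1 `O=C(Nc1ccccc1)Nc1cccc(Nc2nccc(Nc3ccc4[nH]ccc4c3)n2)c1` gives 8.8 mL.min-1.g-1
- Compound 2 `O=C(Nc1ccccc1)Nc1cccc(Nc2nccc(Nc3ccc4cc[nH]c4c3)n2)c1` gives 3.8 mL.min-1.g-1

Compound 2 holds the lower of the two numbers, so it is the slower-cleared of the pair. The next compound to be tested is compound 3 `Cn1cc2ccc(Nc3ccnc(Nc4cccc(NC(=O)Nc5ccccc5)c4)n3)cc2n1`, which keeps everything else in compound 2 and changes a single group (2-methyl-2H-indazol-6-yl in place of 1H-indol-6-yl on a nitrogen on an aromatic ring). The 1H-indol-6-yl leaves and the 2-methyl-2H-indazol-6-yl enters, on a nitrogen on an aromatic ring.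

Going by the values given here, only one measured step touches this place, and it is modest (a 2.3-fold lower number from compound 1 to compound 2 (0.36 log units; beyond the scatter)). Among the compounds with values here, that step swapped 1H-indol-5-yl for 1H-indol-6-yl, which is a different change from the one in compound 3, so it is only a loose guide. Within the data shown here, it shows that a change here can move the number, but no measured compound carries the 2-methyl-2H-indazol-6-yl, and the direction therefore stays open. The expected size is small, with a 1.3-fold higher number from compound 2 to compound 3 (0.12 log units; within the scatter) as the estimated step and no firm direction. Compound 3 is estimated at 5 mL.min-1.g-1 (expected range 2 mL.min-1.g-1 to 12 mL.min-1.g-1).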

Compound 3, intrinsic clearance in microsomes in the Mus musculus assay: > 50 mL.min-1.g-1
Compound 3 was reported as a limit (the forecaster's own chance of this, stated with the estimate: 5%); at least 10-fold (1.00 log units) between middle value and limit.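

In the Mus musculus assay, putting 2-methyl-2H-indazol-6-yl on a nitrogen on an aromatic ring gives an at least 13-fold higher number from compound 2 to compound 3 (1.11 log units; beyond the scatter) and an at least 5.6-fold higher number from compound 1 to compound 3 (0.75 log units; beyond the scatter), so this place can shift clearance much further than moving the indole attachment did, which gave only a 2.3-fold lower number from compound 1 to compound 2 (0.36 log units; beyond the scatter). For compound 3, > 50 mL.min-1.g-1 is a limit of the assay and not a number. In a physicochemical assay for solubility, read by HPLC, in phosphate buffer, at pH 7.4 (a higher number here means a more soluble compound, a lower number a less soluble compound), compound 2 gives 0.44 ug/mL and compound 3 gives 0.11 ug/mL. The same swap from compound 2 also goes with a poorer reading in the physicochemical assay: the measured solubility of compound 2, 0.44 ug/mL, and of compound 3, 0.11 ug/mL, a 4.0-fold lower number (0.60 log units; beyond the scatter)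

The compounds shown do not separate the hydrogen-bond donor that leaves from the nitrogen and the methyl group that enter, so which of these changes matters for clearance or solubility stays open. Also open, on these data alone, is how 1H-indazol-6-yl, which has no methyl group, or a 2-ethyl-2H-indazol-6-yl with a longer chain, would read in the Mus musculus assay and the physicochemical assay.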